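The source may hold more compounds than are shown below. What is called first, only, known or untested is meant among the compounds shown, and "the series" means these compounds.

Measured compounds:
Compound 1 `O=C(O)Cc1sc(C(c2ccc(F)cc2)c2ccc(F)cc2)nc1-c1ccnc(N2CCCC2)c1`: 80%
Compound 2 `O=C(O)Cc1sc(C(c2ccccc2)c2ccccc2)nc1-c1cccc(F)c1`: 80%
Compound 3 `O=C(O)Cc1sc(C(c2ccccc2)c2ccc(O)cc2)nc1-c1ccc(F)cc1`: 80%

In an in vitro functional assay on HEK285-7 cells for antagonist activity at prostaglandin D2 receptor 2 (Homo sapiens), read by BRET and beta-arrestin recruitment (on this read-out higher numbers stand for larger maximal responses and lower numbers for smaller maximal responses), compound 1 stands level with compound 2 and compound 3; the three values lie within the scatter of one another, compound 2 being the nearest and compound 3 the furthest, and neither differs from compound 1 at the digits shown. Compound 4 `O=C(O)Cc1sc(C(c2ccc(F)cc2)c2ccc(F)cc2)nc1-c1ccoc1` has not yet been measured in this assay. It differs from compound 1 in one place: furan-3-yl in place of 2-(pyrrolidin-1-yl)pyridin-4-yl on an aromatic carbon. Among the measured compounds shown here, no measured pair shows what this change does, so the expectation rests on the standing of compound 1 alone. Compound 4 is expected to give a small downward step in this assay, a number 5 percentage points lower from compound 1 to compound 4 (within the scatter), which is expected to remain close to the scatter. The estimate for compound 4 is 75%, between 55% and 95%.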

Compound 4, largest response reached (reported as efficacy), in percent of the reference or control that the assay uses: 80%
Beside the measured number, compound 4's estimate is 5 percentage points below it; the range from low to high includes it.
By their numbers in this assay, from the lowest: compounds 1, 2, 3 and 4 (each within the scatter of the next).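

In this assay, putting furan-3-yl in place of 2-(pyrrolidin-1-yl)pyridin-4-yl on this aromatic carbon gives no change at the digits printed from compound 1 to compound 4 (within the scatter). For this pair, the maximal response therefore does not depend on the pyrrolidine ring or the six-membered aromatic ring, and the smaller furan-3-yl serves equally well at this position. No measurement shown accounts for this result. The compounds shown leave open whether a group of another kind, such as a primary amine, a carboxylic acid or an open alkyl chain, would keep this response at the same position.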